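Series notes: hydroxymethyl entering on the 3,5-dichlorobenzyl side chain

The source may hold more compounds than are shown below. What is called first, only, known or untested is meant among the compounds shown, and "the series" means these compounds.

Compound 3 `O=C(O)c1cncc(CN2CCC[C@H](OCc3cc(Cl)cc(Cl)c3)[C@@H]2c2ccccc2)c1` gives 117000 nM in an assay on isolated protein for activation of cGMP-dependent protein kinase 1 (Homo sapiens), read by ADP-Glo, with stated times of 120 min and 40 min (on this read-out lower numbers stand for an effect already at smaller amounts and higher numbers for an effect only at larger amounts of compound), the highest number of the three measured; compound 1 `OC[C@@H](O[C@H]1CCCN(Cc2ncc[nH]2)[C@H]1c1ccccc1)c1cc(Cl)cc(Cl)c1` gives 7000 nM and compound 2 `OC[C@@H](O[C@H]1CCCN(Cc2ccccc2Cc2nnco2)[C@H]1c1ccccc1)c1cc(Cl)cc(Cl)c1` gives 3700 nM. Going by the values given here, the only single-place step measured, a 1.9-fold lower number from compound 1 to compound 2 (0.28 log units; within the scatter), concerns a different position and does not bear on the change at hand. Compound 4 `O=C(O)c1cncc(CN2CCC[C@H](O[C@H](CO)c3cc(Cl)cc(Cl)c3)[C@@H]2c2ccccc2)c1` differs from compound 3 by hydroxymethyl in place of hydrogen on a saturated chain carbon bound to an aromatic carbon and an oxygen on a saturated carbon. Among the compounds with values here, compounds 1 and 2 carry this hydroxymethyl and give the lower numbers, but each also differs from compound 3 elsewhere, so no clean measured step exists. A lower number for compound 4 is expected, a 2.9-fold lower number from compound 3 to compound 4 (0.47 log units; beyond the scatter), with wide uncertainty. Compound 4 is estimated at 40000 nM, between 10000 nM and 120000 nM.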

Compound 4, half-maximal effective concentration: 34000 nM
Beside the measured number, compound 4's estimate is 1.2-fold (0.07 log units) above it; low and high end bracket the measured number.
By their numbers in this assay, from the lowest: compounds 2 and 1 (each within the scatter of the next); then compound 4; then compound 3.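

In this assay hydroxymethyl in place of hydrogen now has a clean step of its own, a 3.4-fold lower number from compound 3 to compound 4 (0.54 log units; beyond the scatter) as a modest change on the 3,5-dichlorobenzyl side chain alone. Even with hydroxymethyl present, the 5-carboxypyridin-3-yl compound keeps the higher number, with a 4.9-fold higher number from compound 1 to compound 4 (0.69 log units; beyond the scatter) against 1H-imidazol-2-yl and a 9.2-fold higher number from compound 2 to compound 4 (0.96 log units; beyond the scatter) against the larger group of compound 2. No measured evidence accounts for any of these steps.

Going by these compounds, whether hydroxymethyl gives a step of similar size alongside 1H-imidazol-2-yl remains open. So does the effect of methyl or an aminomethyl group in its place on that saturated chain carbon.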